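The source may report more compounds than this note shows. Statements on the series, on what has been measured and on what is new or still open speak of the compounds shown alone.

In a functional assay on PANC-1 cells (Homo sapiens) for antiproliferative activity, read by CCK-8 assay, with a stated time of 72 h (a higher number here means a weaker inhibitor, a lower number a stronger inhibitor), compound 1 `Cc1cc(Nc2cc(N3CCN(C)CC3)nc(Nc3ccc([N+](=O)[O-])cc3)n2)n[nH]1` gives 442 nM, compound 2 `COc1cccc(Nc2nc(Nc3cc(C)[nH]n3)cc(N3CCN(C)CC3)n2)c1` gives 693 nM and compound 3 `Cc1cc(Nc2cc(N3CCN(C)CC3)nc(Nc3cccc([N+](=O)[O-])c3)n2)n[nH]1` gives 457 nM, so compound 3 stands within the scatter of both others. Compound 4 `Cc1cc(Nc2cc(N3CCN(C)CC3)nc(Nc3ccc(C#N)cc3)n2)n[nH]1` is still unmeasured. It differs from compound 3 by 4-cyanophenyl in place of 3-nitrophenyl on a nitrogen on an aromatic ring, with 4-cyanophenyl in place of 3-nitrophenyl on a nitrogen on an aromatic ring. The nearest guides are a 1.0-fold higher number from compound 1 to compound 3 (0.01 log units; within the scatter), for moving between the two nitrophenyl groups, and a 1.5-fold lower number from compound 2 to compound 3 (0.18 log units; within the scatter), for nitro in place of methoxy. With a 1.6-fold higher number from compound 1 to compound 2 (0.20 log units; within the scatter) also small, no step beyond the scatter is expected in this assay. Among the measured compounds shown here, no measured compound carries a nitrile, so the range stays wide. The estimated step is a 1.1-fold higher number from compound 3 to compound 4 (0.02 log units; within the scatter). For compound 4 the estimated value is 480 nM, within a range of 230 nM to 1000 nM.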

Compound 4, half-maximal inhibitory concentration: 435 nM
Estimate against measurement, compound 4: 1.1-fold (0.04 log units) above, and the stated range covers the measured number.
By their numbers in this assay, from the lowest: compounds 4, 1, 3 and 2 (each within the scatter of the next).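

Swapping the nitro group of compound 1 for a nitrile gives a 1.0-fold lower number from compound 1 to compound 4 (0.01 log units; within the scatter) in this assay, so on this ring a group other than nitro can stand without a step beyond the scatter. The comparisons with the other two aryl groups agree, with a 1.1-fold lower number from compound 3 to compound 4 (0.02 log units; within the scatter) and a 1.6-fold lower number from compound 2 to compound 4 (0.20 log units; within the scatter), so all three changes at this nitrogen stay within the scatter. Nothing on hand bears on what lies behind these small steps. On these data alone, whether an amine or a carboxylic acid on this phenyl ring would also stay within the scatter remains open.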